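This account rests on a few compounds, and the source may have more. Where it says the series, first, only, none or still open, it means among the compounds named here.

Series notes. For the measured compounds named here, compound 2 `Cc1cc(C(C)CC(=O)O)ccc1-c1noc(-c2ccc(OC(C)C)c(C(F)(F)F)c2)n1` carries the acid on a branched side chain; in a functional assay on CHO cells for displacement of a labelled ligand from sphingosine 1-phosphate receptor 5 (Homo sapiens), read by GTPgammaS binding (on this read-out higher numbers stand for an effect only at larger amounts of compound and lower numbers for an effect already at smaller amounts), compound 2 gives 3.9 nM, the lowest of the three numbers measured so far. Compound 1 `Cc1cc([C@@H]2C[C@H]2C(=O)O)ccc1-c1noc(-c2ccc(OC(C)C)c(C(F)(F)F)c2)n1`, with the ring-closed version of that side chain, gives 5.1 nM in this assay; the step of a 1.3-fold lower number from compound 1 to compound 2 (0.12 log units; within the scatter) is within the scatter, so compound 1 and compound 2 cannot be told apart. Going by the values given here, compound 3 `Cc1nc(CCC(=O)O)ccc1-c1noc(-c2ccc(OC(C)C)c(C#N)c2)n1` gives 28.6 nM in this assay, a number beyond the scatter from compound 2, but its core and its side chain both differ from those of compound 2, and no single step connects the two.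

Compound 4 `Cc1cc(CC(C)C(=O)O)ccc1-c1noc(-c2ccc(OC(C)C)c(C(F)(F)F)c2)n1` differs from compound 2 by 2-carboxypropyl in place of 1-(carboxymethyl)ethyl on an aromatic carbon. Among the compounds with values here, the only measured step that bears on this change is a 1.3-fold lower number from compound 1 to compound 2 (0.12 log units; within the scatter), which reshaped the same side chain and stayed within the scatter; a further rearrangement of the same atoms is therefore expected to move the number little, with no direction claimed. The step expected here, a 1.4-fold higher number from compound 2 to compound 4 (0.15 log units; within the scatter), is small. Compound 4 is estimated at 5.5 nM in this assay, with a range of 2 nM to 15 nM.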

Compound 4, half-maximal effective concentration: 9.9 nM
For compound 4 the middle estimate is 1.8-fold (0.26 log units) below the measured one, within the range that was stated.
By their numbers in this assay, from the lowest: compounds 2, 1 and 4 (each within the scatter of the next, the first and the last beyond it); then compound 3.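

With the same atoms joined differently, 2-carboxypropyl in place of 1-(carboxymethyl)ethyl on this aromatic carbon, para to a large group, gives a change in this assay that lies beyond the scatter (a 2.5-fold higher number from compound 2 to compound 4 (0.40 log units; beyond the scatter)), so this position can register a rearrangement of the side chain alone, which the earlier step did not show. The step from the ring-closed side chain stays within the scatter (a 1.9-fold higher number from compound 1 to compound 4 (0.29 log units; within the scatter)), so compound 1 and compound 4 cannot be told apart. Nothing available accounts for the difference between these side chains.

The compounds shown leave open whether the same rearrangement gives a comparable step on the core of compound 3. Also open, on these data alone, is how a longer chain bearing the carboxylic acid, or an amine in place of that acid, would read at this position.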